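Replacing a benzothiazolylsulfanyl group by chloro on the ester side chain

This account rests on a few compounds, and the source may have more. Where it says the series, first, only, none or still open, it means among the compounds named here.

The study measures cytotoxicity in a functional assay on A549 cells (Homo sapiens) for cytotoxicity, read by MTT assay, with a stated time of 72 h; a lower number here means a stronger inhibitor, a higher number a weaker inhibitor. Compound 2 `C=C1C2=C(C(=O)N1OC)[C@H](OC(=O)CSc1nc3ccccc3s1)[C@@](C)(O)[C@H](CCCCC)O2` gives 5900 nM and holds the lowest of the three numbers available. Compound 1 `C=C1C2=C(C(=O)N1OC)[C@H](OC(=O)CSc1nc3ccccc3o1)[C@@](C)(O)[C@H](CCCCC)O2` gives 20000 nM, and compound 3 `C=C1C2=C(C(=O)N1OC)[C@H](O)[C@@](C)(O)[C@H](CCCCC)O2`, which carries a free hydroxyl in place of the ester, gives 41000 nM. Among the measured compounds shown here, the one measured step, a 3.4-fold lower number from compound 1 to compound 2 (0.53 log units; beyond the scatter), shows that exchanging the heteroaromatic group attached to the sulfur moves the number by a modest amount.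

Compound 4 `C=C1C2=C(C(=O)N1OC)[C@H](OC(=O)CCl)[C@@](C)(O)[C@H](CCCCC)O2` differs from compound 2 in this way: chloro in place of (1,3-benzothiazol-2-yl)sulfanyl on a saturated chain carbon bound to a carbonyl carbon. For the measured compounds named here, no measured step bears directly on this change. What the data show is that compound 2 and compound 1 both carry a large ester side chain and sit well below compound 3, which carries none. Compound 4 keeps an ester but loses the whole heteroaromatic part, so its number is expected to land between these, with a step of a 2.5-fold higher number from compound 2 to compound 4 (0.41 log units; beyond the scatter) expected from compound 2 to compound 4. Compound 4 is therefore estimated at 15000 nM, with a range of 4000 nM to 60000 nM.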

Compound 4, half-maximal inhibitory concentration: 20000 nM
Estimate against measurement, compound 4: 1.3-fold (0.12 log units) below; measured number inside the range.
By their numbers in this assay, from the lowest: compound 2; then compounds 1 and 4 (each within the scatter of the next); then compound 3.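

In this assay, chloro in place of (1,3-benzothiazol-2-yl)sulfanyl on this saturated chain carbon gives a 3.4-fold higher number from compound 2 to compound 4 (0.53 log units; beyond the scatter), so the heteroaromatic part of compound 2 counts for something beyond the ester alone. The ester itself also counts: (chloromethyl)carbonyl in place of hydrogen on the oxygen gives a 2.1-fold lower number from compound 3 to compound 4 (0.31 log units; beyond the scatter), although no ring has been added. Chloro in place of (1,3-benzoxazol-2-yl)sulfanyl gives no change at the digits printed from compound 1 to compound 4 (within the scatter), so among these three esters only the benzothiazole-bearing compound 2 stands apart from the simple chloro ester. From the compounds shown here alone, whether an amine or a plain phenyl ring on this chain carbon would behave like chloro or like the (1,3-benzothiazol-2-yl)sulfanyl group remains open. Nothing available explains why these groups differ.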